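Trading ethyl for chloro in compound 3

The source may hold more compounds than are shown below. What is called first, only, known or untested is meant among the compounds shown, and "the series" means these compounds.

In a physicochemical assay for lipophilicity, read by mass spectrometry (on this read-out higher numbers stand for higher lipophilicity and lower numbers for lower lipophilicity), compound 3 (`CCc1cccc(NC(=O)C2Cc3cc(OC)c(OC)cc3C2=O)c1`) gives 3.11. Compound 1 (`CCc1ccc(NC(=O)C2Cc3cc(OC)c(OC)cc3C2=O)cc1`) gives 3.11, level with it at the digits shown, and the two share the highest number of the three compounds measured so far. Compound 2 (`COc1cc2c(cc1OC)C(=O)C(C(=O)Nc1ccc(F)cc1)C2`) gives 2.36.

The next compound, compound 4 (`COc1cc2c(cc1OC)C(=O)C(C(=O)Nc1cccc(Cl)c1)C2`), keeps the shared core and alters one group: chloro in place of ethyl on an aromatic carbon. In short, it has chloro in place of ethyl on an aromatic carbon.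

Going by the values given here, two measured steps bear on this change. Putting 3-ethylphenyl in place of 4-ethylphenyl gave no change at the digits printed from compound 1 to compound 3 (within the scatter), so moving the ethyl group left the number where it was. Among the compounds with values here, putting fluoro in place of ethyl gave a number 0.75 log units lower from compound 1 to compound 2 (beyond the scatter), and this is the closest precedent for losing ethyl. Within the data shown here, no measured compound carries chloro, and that step guides the direction more firmly than the size. A lower number is expected here, by a step smaller than the fluoro one and close to the edge of the scatter. The expected change is a number 0.31 log units lower from compound 3 to compound 4 (beyond the scatter). For compound 4 the estimated value is 2.8, with an expected range from 2.5 to 3.1.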

Compound 4, partition coefficient: 2.76
Estimate against measurement, compound 4: 0.04 log units above; the range from low to high includes it.
By their numbers in this assay, from the lowest: compound 2; then compound 4; then compounds 1 and 3 (each within the scatter of the next).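

In this assay, the identity of the group on this ring carbon matters, and not only its location: with chloro in place of ethyl there is a number 0.35 log units lower from compound 3 to compound 4 (beyond the scatter), whereas the earlier move of the ethyl group alone left the number unchanged at the digits printed. Compound 4 also gives the series its first middle position, with a number 0.35 log units lower from compound 1 to compound 4 (beyond the scatter) on one side and a number 0.40 log units higher from compound 2 to compound 4 (beyond the scatter) on the other, although each of these two steps changes both the group and its place on the ring. Nothing measured here gives a reason for these steps.

The compounds shown leave open whether chloro would read the same at another place on the ring, as ethyl did, so the fluoro and chloro steps cannot yet be separated from the change of place. They also leave open how other groups at this ring carbon would compare, such as bromo, trifluoromethyl, an amine or a longer chain like propyl.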